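The compounds below may be only part of what the source reports. "The series", "measured", "known", "first", "only" and "open" are said of these compounds alone.

Among the measured compounds shown here, compound 1 `COc1ccc(C(=O)c2cc(OC)c(OC)c(OC)c2)cc1NC(=O)/C=C/c1cc(OC)c(OC)c(OC)c1` stands highest of the three numbers measured so far: in a functional assay on HT-29 cells (Homo sapiens) for cytotoxicity, read by MTT assay, with a stated time of 72 h (a lower number here means a stronger inhibitor, a higher number a weaker inhibitor), compound 1 gives 3100 nM. Its nearest neighbour is compound 2 `COc1ccc(C(=O)c2cc(OC)c(OC)c(OC)c2)cc1NC(=O)/C=C/c1ccc(OC)c(OC)c1`, which in this assay gives 2500 nM; the step of a 1.2-fold lower number from compound 1 to compound 2 (0.09 log units; within the scatter) came from a hydrogen in place of methoxy on an aromatic carbon. The furthest is compound 3 `COc1ccc(C(=O)c2cc(OC)c(OC)c(OC)c2)cc1NC(=O)/C=C/c1ccc(F)cc1`, which gives 1800 nM in this assay; the step of a 1.7-fold lower number from compound 1 to compound 3 (0.24 log units; within the scatter) came from 4-fluorophenyl in place of 3,4,5-trimethoxyphenyl on a double-bonded chain carbon bound to a double-bonded chain carbon. The step of a 1.4-fold lower number from compound 2 to compound 3 (0.14 log units; within the scatter) came from the same 4-fluorophenyl in place of 3,4-dimethoxyphenyl.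

Compound 4 `COc1ccc(C(=O)c2cc(OC)c(OC)c(OC)c2)cc1NC(=O)/C=C/c1ccc(F)c(F)c1` has not been measured. It differs from compound 1 in one place: 3,4-difluorophenyl in place of 3,4,5-trimethoxyphenyl on a double-bonded chain carbon bound to a double-bonded chain carbon. The closest measured guide is the step of a 1.7-fold lower number from compound 1 to compound 3 (0.24 log units; within the scatter), which also replaced the 3,4,5-trimethoxyphenyl with a fluorine-bearing phenyl and stayed within the scatter, as did a 1.4-fold lower number from compound 2 to compound 3 (0.14 log units; within the scatter). For the measured compounds named here, the difference between 4-fluorophenyl and 3,4-difluorophenyl has no measured counterpart here. The number for compound 4 is therefore expected to sit near that of compound 3, giving an expected step of a 1.9-fold lower number from compound 1 to compound 4 (0.29 log units; within the scatter), a lower number but not clearly beyond the scatter. For compound 4 the estimate in this assay is 1600 nM, with a range from 700 nM to 3600 nM.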

Compound 4, half-maximal inhibitory concentration: 4200 nM
Compound 4: the middle estimate sits 2.6-fold (0.42 log units) below what was measured; the whole stated range lies below it.
By their numbers in this assay, from the lowest: compounds 3, 2, 1 and 4 (each within the scatter of the next, the first and the last beyond it).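

In this assay, among the compounds shown here, the step of a 2.3-fold higher number from compound 3 to compound 4 (0.37 log units; beyond the scatter) is the first to pass beyond the scatter, so a single fluoro in place of hydrogen on this phenyl ring can produce a measurable change, though a modest one. The swaps of the methoxy-bearing rings for 3,4-difluorophenyl, a 1.4-fold higher number from compound 1 to compound 4 (0.13 log units; within the scatter) and a 1.7-fold higher number from compound 2 to compound 4 (0.23 log units; within the scatter), both stay within the scatter, so compound 4 cannot be told apart from compound 1 or compound 2, and the two fluorine-bearing compounds, compound 3 and compound 4, do not behave as one group. Nothing available here accounts for the step gained with the second fluoro.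

The compounds shown leave open how this ring position responds to groups of another kind, such as a chloro, a trifluoromethyl, an amine or a carboxylic acid in place of the fluoro. For the compounds shown here, it also remains open whether adding a fluoro would produce a step of similar size on a ring that also carries methoxy groups, since the one step available comes from a single pair of compounds.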